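Benzyl on the ring amine: one change, measured once

The source may hold more compounds than are shown below. What is called first, only, known or untested is meant among the compounds shown, and "the series" means these compounds.

Compound 1 `CCNS(=O)(=O)c1ccc(NC2CCCC2)c(N)c1`: 82 nM
Compound 2 `CNS(=O)(=O)c1ccc(NC2CCCCC2)c(N)c1`: 76 nM
Compound 3 `CCNS(=O)(=O)c1ccc(NC2CCCC2)c(NCc2ccccc2)c1`: 8.2 nM

In a functional assay (IMR-32 cells, Homo sapiens) for inhibition, read by fluorescence, with stated times of 1 h and 13 h (on this read-out lower numbers stand for stronger inhibition and higher numbers for weaker inhibition), compound 1 gives 82 nM and compound 2 gives 76 nM; these two lie within the scatter of each other. The two cores differ, but that difference is not broken down here. Compound 3 `CCNS(=O)(=O)c1ccc(NC2CCCC2)c(NCc2ccccc2)c1` arises from compound 1 by benzyl in place of hydrogen on a nitrogen on an aromatic ring, and this gives a 10-fold lower number from compound 1 to compound 3 (1.00 log units; beyond the scatter). Compound 4 `CNS(=O)(=O)c1ccc(NC2CCCCC2)c(NCc2ccccc2)c1` arises from compound 2 by the same kind of change, (benzyl in place of hydrogen on a nitrogen on an aromatic ring), on the core of compound 2. The two place descriptions read the same. Because compound 1 to compound 3 shows a 10-fold lower number from compound 1 to compound 3 (1.00 log units; beyond the scatter), the step from compound 2 to compound 4 is expected to be about a 10-fold lower number from compound 2 to compound 4 (1.00 log units; beyond the scatter) in this assay. Compound 4 is therefore estimated at 7.6 nM, with a likely range from 3 nM to 20 nM.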

Compound 4, half-maximal inhibitory concentration: 3.7 nM
For compound 4 the middle estimate is 2.1-fold (0.31 log units) above the measured one; low and high end bracket the measured number.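

In this assay, benzyl in place of hydrogen on a nitrogen on an aromatic ring gives a 21-fold lower number from compound 2 to compound 4 (1.31 log units; beyond the scatter) on the second core, so the number falls clearly on both cores. The two steps agree as closely as such measurements can show: the same change on two cores in this assay, a 10-fold lower number (1.00 log units; beyond the scatter) from compound 1 to compound 3 and a 21-fold lower number (1.31 log units; beyond the scatter) from compound 2 to compound 4, 2.1-fold (0.31 log units) apart, within the scatter of two such steps

This supports carrying the change between these two closely related cores, but with one pair on each core it says nothing about any other core and does not explain the gain.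

The compounds shown leave open whether methyl or a longer chain such as phenylethyl on the same nitrogen would do as well as benzyl. They also leave open how much each part of the difference between the two cores contributes.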